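This account rests on a few compounds, and the source may have more. Where it says the series, first, only, none or still open, it means among the compounds named here.

The series shares the core of compound 1 `O=C(CCCCCCNC(=O)C(O)(O)C(F)(F)F)Nc1cccc(Br)c1` and varies only the group on the amide-type nitrogen. In a functional assay on HCT-116 cells (Homo sapiens) for inhibition, read by colorimetric assay, with a stated time of 3 days (a higher number here means a weaker inhibitor, a lower number a stronger inhibitor), compound 1 gives 3060 nM, compound 2 `O=C(CCCCCCNC(=O)C(O)(O)C(F)(F)F)Nc1ccc(F)cc1` gives 7570 nM and compound 3 `O=C(CCCCCCNC(=O)C(O)(O)C(F)(F)F)Nc1ccncc1` gives 6670 nM. Compound 2 has the highest of the three numbers; nearest is compound 3, with a 1.1-fold lower number from compound 2 to compound 3 (0.05 log units; within the scatter), furthest compound 1, with a 2.5-fold higher number from compound 1 to compound 2 (0.39 log units; beyond the scatter). Compound 4 `O=C(CCCCCCNC(=O)C(O)(O)C(F)(F)F)Nc1ccc(-c2ccccc2)cc1` differs from compound 2 by phenyl in place of fluoro on an aromatic carbon. Among the compounds with values here, no measured step exchanges fluoro for phenyl; the steps of a 2.5-fold higher number from compound 1 to compound 2 (0.39 log units; beyond the scatter) and a 2.2-fold higher number from compound 1 to compound 3 (0.34 log units; beyond the scatter) show only that varying the aryl group moves this assay modestly. A shift of similar size in either direction is plausible, the lower side slightly favoured. Compound 4 is thus expected near 4500 nM, within 1500 nM to 14000 nM, an estimated step of a 1.7-fold lower number from compound 2 to compound 4 (0.23 log units; within the scatter).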

Compound 4, half-maximal inhibitory concentration: 4730 nM
For compound 4 the middle estimate is 1.1-fold (0.02 log units) below the measured one; low and high end bracket the measured number.
By their numbers in this assay, from the lowest: compounds 1, 4, 3 and 2 (each within the scatter of the next, the first and the last beyond it).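

On the aromatic carbon para to a large group, phenyl in place of fluoro puts six heavy atoms where one stood, and in this assay the result stays within the scatter (a 1.6-fold lower number from compound 2 to compound 4 (0.20 log units; within the scatter)). The earlier steps shown here exchange the whole group on the amide-type nitrogen, whereas this one adds a further ring at a single position, and that ring is accepted here. On these data alone, whether an amine or a carboxylic acid on this aromatic carbon would behave alike stays open, as does the effect of a longer chain in the shared core. No measurement on hand explains this result.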